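From ethoxy to a furan-bearing propoxy chain

The source may report more compounds than this note shows. Statements on the series, on what has been measured and on what is new or still open speak of the compounds shown alone.

In a functional assay on PANC-1 cells (Homo sapiens) for inhibition, read by MTT assay, with a stated time of 24 h (a lower number here means a stronger inhibitor, a higher number a weaker inhibitor), compound 1 `CCOc1cc(=O)n(CCCO)c2c1CC(CC=C(C)C)C(C)(C)C2` gives 7300 nM and compound 2 `CCOc1cc(=O)n(CCCO)c2c1CC(C/C=C(\C)CCC=C(C)C)C(C)(C)C2` gives 5800 nM. Going by the values given here, these two values lie within the scatter of each other, so compound 2 stands level with the only other measured compound. Among the compounds with values here, the one measured step, a 1.3-fold lower number from compound 1 to compound 2 (0.10 log units; within the scatter), places 3-methylbut-2-en-1-yl in place of hydrogen on a saturated chain carbon bound to a double-bonded chain carbon, and it stays within the scatter.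

Compound 3 `CC(C)=CCC/C(C)=C/CC1Cc2c(OCCCNC(=O)c3ccco3)cc(=O)n(CCCO)c2CC1(C)C` differs from compound 2 at another place: (((furan-2-yl)carbonyl)amino)methyl in place of hydrogen on a saturated chain carbon, two bonds along the chain from an oxygen on an aromatic ring. Put more simply, ethoxy becomes 3-(((furan-2-yl)carbonyl)amino)propoxy. Within the data shown here, no measured pair shows a change at this place, so a 1.3-fold lower number from compound 1 to compound 2 (0.10 log units; within the scatter) offers only an indirect guide. With so little evidence, no step beyond the scatter is expected in this assay, and the direction remains uncertain. The expected change is a 1.5-fold lower number from compound 2 to compound 3 (0.16 log units; within the scatter), which would stay within the scatter. For compound 3 the estimated value is 4000 nM, with an expected range of 1300 nM to 12000 nM.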

Compound 3, half-maximal inhibitory concentration: 5200 nM
Estimate against measurement, compound 3: 1.3-fold (0.11 log units) below, within the range that was stated.
By their numbers in this assay, from the lowest: compounds 3, 2 and 1 (each within the scatter of the next).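

Going by these compounds alone, this is the first measured change at this position, on a saturated chain carbon, two bonds along the chain from an oxygen on an aromatic ring, and in this assay ethoxy becoming 3-(((furan-2-yl)carbonyl)amino)propoxy gives a 1.1-fold lower number from compound 2 to compound 3 (0.05 log units; within the scatter), so compound 3 stands level with compound 2. The entering group brings 9 heavy atoms, one five-membered aromatic ring, 1 hydrogen-bond donor and 2 hydrogen-bond acceptors, yet the number stays inside the usual scatter of this assay, which shows that this position can carry such a group without a measurable step in either direction. Nothing available explains why the reading holds level, and no other measurement bears on this result.

As far as these compounds go, compound 2 and compound 3 mark only the two ends of this change, so it remains open which part of the new group, the longer chain, the amide or the furan-2-yl ring, would matter on its own. Also open, from the compounds shown here alone, is whether a different group here, such as 3-aminopropoxy, 3-carboxypropoxy or a benzoyl amide in place of the furan-2-yl amide, would move the number beyond the scatter.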